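Shifting the acid side chain on a shared biaryl ether core

The source may report more compounds than this note shows. Statements on the series, on what has been measured and on what is new or still open speak of the compounds shown alone.

Of the compounds shown here, two on a common core have been measured. Compound 1 `Cc1cccc(C)c1-c1cccc(COc2cnc(CCC(=O)O)cn2)c1` gives 3.8 nM in a functional assay on CHO cells for agonist activity at Free fatty acid receptor 1 (Homo sapiens), read by calcium flux; on this read-out lower numbers stand for an effect already at smaller amounts and higher numbers for an effect only at larger amounts of compound. Compound 2 `Cc1cccc(C)c1-c1cccc(COc2ccc(CC(C)C(=O)O)cn2)c1` gives 65 nM in this assay, the higher of the two numbers; the gap to compound 1 lies beyond the scatter, so compound 2 stands as the weaker of the pair.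

Compound 3 `CCOC(CC(=O)O)c1ccc(OCc2cccc(-c3c(C)cccc3C)c2)nc1` has not yet been measured. It differs from compound 2 in one place: 2-carboxy-1-ethoxyethyl in place of 2-carboxypropyl on an aromatic carbon. The acid chain grows by an ethoxy substituent and keeps its single carboxylic acid.

Within the data shown here, no measured pair shows what such a change does on this core, so any expectation rests on the two numbers above. Compound 1 shows the core can reach a low number in this assay, while compound 2 shows how much a different acid chain can cost. The step from compound 2 to compound 3 is expected to be modest, toward a lower number, a 2.2-fold lower number from compound 2 to compound 3 (0.34 log units; beyond the scatter), and may not exceed the scatter. Compound 3 is therefore estimated at 30 nM, within a range from 8 nM to 120 nM.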

Compound 3, half-maximal effective concentration in the Free fatty acid receptor 1 assay: 14 nM
For compound 3 the middle estimate is 2.1-fold (0.33 log units) above the measured one; measured number inside the range.
By their numbers in the Free fatty acid receptor 1 assay, from the lowest: compound 1; then compound 3; then compound 2.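

On the aromatic carbon two atoms from the ring nitrogen, para to a large group, the acid chain accepts a larger substituent without loss: in the Free fatty acid receptor 1 assay 2-carboxy-1-ethoxyethyl in place of 2-carboxypropyl gives a 4.6-fold lower number from compound 2 to compound 3 (0.67 log units; beyond the scatter), a step that shows the added ethoxy substituent and the extra hydrogen-bond acceptor counted with it are compatible with a lower number at this position. Among these compounds, in a physicochemical assay for lipophilicity, at pH 7.4 (a higher number here means a more lipophilic compound, a lower number a more polar compound), compound 2 reads "not determined" (no result reported), while compound 3 gives 2.8, so that number stands alone here and supports no comparison within the pair. Nothing in the material at hand explains the step in the Free fatty acid receptor 1 assay.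

The compounds shown do not separate the oxygen of the ethoxy substituent from its carbons, so a methoxy group or a plain propyl group on the same chain carbon would be needed to tell which part of the change goes with the lower number. Also open, going by these compounds, are how a hydroxyl group or a longer alkoxy chain would fare there, and whether the ethoxy substituent would give a similar step on the core of compound 1.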